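A Nitro Group Added to Compound 3

The compounds below may be only part of what the source reports. "The series", "measured", "known", "first", "only" and "open" are said of these compounds alone.

Of the compounds shown here, three have been measured in a functional assay on A549 cells (Homo sapiens) for antiproliferative activity, read by MTT assay, with a stated time of 72 h; a higher number here means a weaker inhibitor, a lower number a stronger inhibitor. Compound 1 `O=C(CCCCCCc1nc(-c2ccccc2Cl)no1)NO` gives 8870 nM, compound 2 `O=C(CCCCCCc1nc(-c2cccnc2)no1)NO` gives 5340 nM, and compound 3 `Nc1ccccc1NC(=O)CCCCCCc1nc(-c2ccccc2)no1` gives 23900 nM. Compound 3 thus has the highest number of the three, and its gap to each of the other two lies beyond the usual scatter.

Compound 4 `Nc1ccccc1NC(=O)CCCCCCc1nc(-c2ccc([N+](=O)[O-])cc2)no1` has not yet been measured. It differs from compound 3 by nitro in place of hydrogen on an aromatic carbon, para to a large group, which turns phenyl into 4-nitrophenyl: nitro in place of hydrogen on an aromatic carbon.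

Among the measured compounds shown here, only one measured step bears on this change, and only indirectly. Pyridin-3-yl in place of 2-chlorophenyl on an aromatic carbon gives a 1.7-fold lower number from compound 1 to compound 2 (0.22 log units; within the scatter), a step within the scatter. For the measured compounds named here, no measured compound carries a nitro group, so the data offer no direct precedent for it. On this thin evidence, no change beyond the scatter is expected in this assay, and no direction can be favoured with confidence. The estimated step is a 1.1-fold lower number from compound 3 to compound 4 (0.04 log units; within the scatter), which is expected to stay within the scatter. Compound 4 is therefore estimated at 22000 nM, with an expected range from 9000 nM to 50000 nM.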

Compound 4, half-maximal inhibitory concentration: > 100000 nM
Compound 4 was reported as a limit; the forecaster's own chance of this, stated with the estimate: 7%; middle value at least 4.5-fold (0.65 log units) from the limit.
By their numbers in this assay, from the lowest: compounds 2 and 1 (each within the scatter of the next); then compound 3. At a limit, above all of these: compound 4.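

In this assay compound 4 gives > 100000 nM, which is a limit of the assay and not a number. Nitro in place of hydrogen on an aromatic carbon, para to a large group, brings an at least 4.1-fold higher number from compound 3 to compound 4 (0.62 log units; beyond the scatter), so this position responds to a change by more than the scatter, and in the direction of weaker inhibition, whereas the only earlier step, a 1.7-fold lower number from compound 1 to compound 2 (0.22 log units; within the scatter), stayed within the scatter and involved a different change in a different pair of compounds. The full size of the new step cannot be read past this limit, so it stands only as a lower bound: the limit of > 100000 nM in this assay, at which 1 of the 4 values shown sits.

The compounds shown leave open whether this weakening belongs to the nitro group itself or would follow any group at this position, such as an amine, a methoxy group or a carboxylic acid in place of the hydrogen. They also leave open whether a nitro group on the aromatic ring of compound 1 or compound 2 would have a similar effect, and whether the same group would act alike at another position on the ring of compound 3.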